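A few compounds are considered here, and "the series" means these few. Any claim that something is new, unique, unknown or untested is made for them only; others in the source may bear on it.

Compound 1 `O=c1[nH]cnc2c1c(-c1ccsc1)cn2[C@@H]1O[C@H](CO)[C@@H](O)[C@H]1O` in a functional assay on HepG2 cells (Homo sapiens) for antiproliferative activity, read by XTT assay, with a stated time of 72 h (a higher number here means a weaker inhibitor, a lower number a stronger inhibitor), gives > 15000 nM, which is a limit of the assay and not a number. Compound 2 `CNc1ncnc2c1c(-c1cccs1)cn2[C@@H]1O[C@H](CO)[C@@H](O)[C@H]1O` in this assay gives > 20000 nM, also a limit. Compound 3 `CNc1ncnc2c1c(-c1cc3ccccc3o1)cn2[C@@H]1O[C@H](CO)[C@@H](O)[C@H]1O` in this assay gives > 20000 nM, again a limit.

Compound 1 thus stands at the limit of > 15000 nM in this assay, at which 1 of the 3 values shown sits, with no number of its own to place it among the others. The two remaining values sit at the limit of > 20000 nM in this assay, at which 2 of the 3 values shown sit. Among the compounds with values here, the single step between measured compounds, a step that the two limits leave unreadable from compound 2 to compound 3, is left unreadable, both of its ends being limits, and it concerns another exchange on the five-membered ring.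

Compound 4 `O=c1[nH]cnc2c1c(-c1ccoc1)cn2[C@@H]1O[C@H](CO)[C@@H](O)[C@H]1O` differs from compound 1 by furan-3-yl in place of thiophen-3-yl on an aromatic carbon. Within the data shown here, no measured step reports the exchange of thiophen-3-yl for furan-3-yl, so the expectation rests on compound 1 alone, which in this assay sits at the limit of > 15000 nM in this assay, at which 1 of the 3 values shown sits. With all three measured compounds at limits, there is no sign that a small change on this ring moves the read-out into the measurable range. Compound 4 is therefore expected to give 20000 nM, within 8000 nM to 60000 nM, most probably reported as a limit once more. The expected step that the limit leaves unreadable from compound 1 to compound 4 is no change beyond the scatter.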

Compound 4, half-maximal inhibitory concentration: 12100 nM
Compound 4: middle estimate off by 1.7-fold (0.22 log units), on the high side, and the stated range covers the measured number.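

In this assay compound 4 gives 12100 nM, the only number among the compounds shown, so with furan-3-yl on this aromatic carbon of the five-membered ring the read-out falls within the measurable range. Compound 1 has only a limit of the assay: the limit of > 15000 nM in this assay, at which 1 of the 4 values shown sits. The exchange of thiophen-3-yl for furan-3-yl is thus an at least 1.2-fold lower number from compound 1 to compound 4 (0.09 log units; that floor lies within the scatter), so the data give this change only a floor and do not establish a real difference in potency between the two groups.

On these data alone, how far the true value of compound 1 lies from that of compound 4 remains open, as does whether the measurable read-out extends beyond furan-3-yl to a phenyl ring or an aminomethyl group on this carbon. Also open, as far as these compounds go, is whether furan-3-yl would give a number with the methylamino group of compound 2 in place of the ring carbonyl of compound 4.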